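Amide-nitrogen substituent variation in a chromone acrylamide series

This account rests on a few compounds, and the source may have more. Where it says the series, first, only, none or still open, it means among the compounds named here.

Measured so far:
compound 1 `COc1ccc2c(=O)c(/C=C/C(=O)Nc3ccccc3Cl)coc2c1`: 23000 nM
compound 2 `COc1ccc2c(=O)c(/C=C/C(=O)NCc3ccc(F)cc3)coc2c1`: 7960 nM

Both numbers come from a functional assay (QGY7701 cells, Homo sapiens) for inhibition, read by MTT assay, with a stated time of 48 h; on this read-out lower numbers stand for stronger inhibition and higher numbers for weaker inhibition. Among the measured compounds shown here, compound 2 gives the lowest of the two numbers; its nearest neighbour is compound 1, and the only measured step is a 2.9-fold lower number from compound 1 to compound 2 (0.46 log units; beyond the scatter), a modest step in which 4-fluorobenzyl replaces 2-chlorophenyl on the amide-type nitrogen.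

The next compound, compound 3 `COc1ccc2c(=O)c(/C=C/C(=O)Nc3ccccc3OC)coc2c1`, differs from compound 2 by 2-methoxyphenyl in place of 4-fluorobenzyl on an amide-type nitrogen. This returns the amide nitrogen to a directly attached aromatic ring, as in compound 1, now carrying 2-methoxyphenyl. For the measured compounds named here, the one bearing step, from compound 1 to compound 2, favoured the benzyl compound, so a step back toward the higher number of compound 1 is expected, of similar or somewhat smaller size, and direction rather than magnitude is the firmer part of the call.

Compound 3 is expected in this assay to give 18000 nM, with a range from 6000 nM to 50000 nM. The expected step is a 2.3-fold higher number from compound 2 to compound 3 (0.35 log units; beyond the scatter).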

Compound 3, half-maximal inhibitory concentration: 17600 nM
For compound 3 the middle estimate is 1.0-fold (0.01 log units) above the measured one, within the range that was stated.
By their numbers in this assay, from the lowest: compound 2; then compounds 3 and 1 (each within the scatter of the next).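

In this assay, moving from 4-fluorobenzyl to 2-methoxyphenyl on the amide-type nitrogen gives a 2.2-fold higher number from compound 2 to compound 3 (0.34 log units; beyond the scatter), so compound 2 now keeps its lower number against two directly attached aromatic rings rather than one. Between those two rings, methoxy in place of chloro on an aromatic carbon gives a 1.3-fold lower number from compound 1 to compound 3 (0.12 log units; within the scatter) and so does not separate compound 1 from compound 3 in this assay. No measurement is available that explains either step.

From the compounds shown here alone, compound 2 alone carries the benzyl link, so it remains open whether its lower number belongs to that link or to the fluorine on its ring. Also open, going by these compounds, is how the amide-type nitrogen would fare with a plain benzyl, an aminoalkyl chain or a carboxylic acid-bearing substituent.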